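The source may hold more compounds than are shown below. What is called first, only, known or untested is meant among the compounds shown, and "the series" means these compounds.

Compound 1 `CCOc1cc(=O)n(CCCO)c2c1CC(CC=C(C)C)C(C)(C)C2` gives 66.5% in a functional assay on PANC-1 cells (Homo sapiens) for inhibition, read by MTT assay, with a stated time of 24 h, tested at 10 uM (a higher number here means more inhibition at the concentration tested (going by the name of the read-out), a lower number less inhibition), the second highest of the three numbers measured. Compound 2 `CC(C)=CCC1Cc2c(OCc3ccccc3)cc(=O)n(CCCO)c2CC1(C)C` gives -0.3% in this assay and compound 3 `CC(C)=CCC1Cc2c(OC(=O)Nc3ccc(F)cc3)cc(=O)n(CCCO)c2CC1(C)C` gives 71.2%. The step of a number 66.8 percentage points lower from compound 1 to compound 2 (beyond the scatter) is large, the step of a number 4.7 percentage points higher from compound 1 to compound 3 (within the scatter) stays within the scatter, and the step of a number 71.5 percentage points higher from compound 2 to compound 3 (beyond the scatter) is large. Compound 4 `CC(C)=CCC1Cc2c(OC(=O)Nc3ccc(Cl)cc3)cc(=O)n(CCCO)c2CC1(C)C` has not been measured; it differs from compound 1 by (4-chlorophenyl)carbamoyl in place of ethyl on an oxygen on an aromatic ring. The closest measured step is a number 4.7 percentage points higher from compound 1 to compound 3 (within the scatter), where (4-fluorophenyl)carbamoyl enters in the same place, so no change beyond the scatter is expected here either. The expected step is a number 3.5 percentage points higher from compound 1 to compound 4 (within the scatter). Compound 4 is thus estimated at 70%, with a range from 55% to 85%.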

Compound 4, a percentage reported as inhibition, at one concentration (the size of the read-out at that concentration, not a potency): 49.8%
Compound 4: the middle estimate sits 20.2 percentage points above what was measured, outside the stated range (below it).
By their numbers in this assay, from the lowest: compound 2; then compound 4; then compounds 1 and 3 (each within the scatter of the next).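

In this assay, chloro in place of fluoro on an aromatic carbon gives a number 21.4 percentage points lower from compound 3 to compound 4 (beyond the scatter), so at this oxygen the outcome depends on the halogen of the carbamoyl group and not on the carbamoyl group alone. With chloro, replacing ethyl now gives a number 16.7 percentage points lower from compound 1 to compound 4 (beyond the scatter), while replacing benzyl still gives a number 50.1 percentage points higher from compound 2 to compound 4 (beyond the scatter). Nothing available here accounts for the gap between chloro and fluoro. Open, on these data alone, is whether bromo or methoxy on that aromatic carbon would read closer to compound 3 or compound 4, and where an unsubstituted phenylcarbamoyl would fall.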